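The source may report more compounds than this note shows. Statements on the series, on what has been measured and on what is new or still open speak of the compounds shown alone.

Compound 1 `CC(C)NC(=O)[C@H]1CC[C@@H](n2/c(=N/C(=O)c3ccc(C#N)c(F)c3)[nH]c3ccc(CN4CCC(C(C)(C)O)CC4)cc32)CC1` was examined in an in vitro ADME assay on microsomes from liver (Rattus norvegicus) for metabolic stability (on this read-out higher numbers stand for fast clearance and lower numbers for slow clearance), where compound 1 gives 29 mL.min-1.g-1. Of the two compounds whose numbers are known outright, compound 1 has the lower one. The closest companion is compound 3 `CCOC(=O)[C@H]1CC[C@@H](n2/c(=N/C(=O)c3ccccc3)[nH]c3ccc(CN4CCCCC4)cc32)CC1`, which in this assay gives 706 mL.min-1.g-1, a higher number that lies beyond the usual scatter of the measurement. Compound 2 `CC(C)NC(=O)[C@H]1CC[C@@H](n2/c(=N/C(=O)c3ccc(F)cc3)[nH]c3ccc(CN4CC(C(C)(C)O)C4)cc32)CC1` returns only a limit of the assay, (the limit of < 14 mL.min-1.g-1 in this assay, at which 1 of the 3 values shown sits), and compound 2 is therefore known in this assay as < 14 mL.min-1.g-1 rather than as a number.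

Compound 4 `CC(C)NC(=O)[C@H]1CC[C@@H](n2/c(=N/C(=O)c3cc(F)cc(Cl)c3)[nH]c3ccc(CN4CCC(C(C)(C)O)CC4)cc32)CC1` has not yet been measured. It differs from compound 1 in one place: 3-chloro-5-fluorophenyl in place of 4-cyano-3-fluorophenyl on a carbonyl carbon. Among the compounds with values here, no pair of measured compounds differing in exactly this way is available, so the size of the step cannot be read from the data. The expectation is that the step from compound 1 to compound 4 is small, perhaps a modest rise that need not exceed the scatter, so that the estimate amounts to a 1.6-fold higher number from compound 1 to compound 4 (0.19 log units; within the scatter). Compound 4 is accordingly expected to give 45 mL.min-1.g-1, within a range from 18 mL.min-1.g-1 to 110 mL.min-1.g-1.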

Compound 4, intrinsic clearance in microsomes: 43 mL.min-1.g-1
Compound 4: middle estimate off by 1.0-fold (0.02 log units), on the high side; measured number inside the range.
By their numbers in this assay, from the lowest: compounds 1 and 4 (each within the scatter of the next); then compound 3. At a limit, below all of these: compound 2.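

Within the data shown here, this is the first step that changes a single place, and in this assay putting 3-chloro-5-fluorophenyl in place of 4-cyano-3-fluorophenyl on a carbonyl carbon gives a 1.5-fold higher number from compound 1 to compound 4 (0.17 log units; within the scatter) with the rest of the molecule held fixed. At this position, then, the nitrile and its hydrogen-bond acceptor can leave and a chlorine can enter without the read-out telling the two compounds apart. None of the measurements shown bears on why these two groups give values so close together.

Going by these compounds, whether an amine or a carboxylic acid on the phenyl ring at this carbonyl carbon would stay as close to compound 1 remains open. On these data alone, the step has also been read only on the background of compound 1, so it is unknown whether it would hold with other groups elsewhere on the shared core.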